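A few compounds are considered here, and "the series" means these few. Any claim that something is new, unique, unknown or untested is made for them only; others in the source may bear on it.

Measured so far in an ADME assay on microsomes from liver (Mus musculus) for metabolic stability, read by LC-MS, with NADPH named in the record, with a stated time of 60 min, tested at 1 uM, in the absence of a further agent; a lower number here means that less of the compound is left, a higher number that more of the compound is left:

compound 1, `CC(=O)N[C@@H]1CCN(c2cc(C)nn3c(-c4cccs4)c(C)nc23)C1`, gives > 95%, a limit of the assay.
compound 2, `CC(=O)N[C@@H]1CCN(c2cc(C)nn3c(-c4nccs4)c(C)nc23)C1`, gives > 95%, also a limit.
compound 3, `COc1ccc(-c2c(C)nc3c(N4CC[C@@H](NC(=O)NC(C)C)C4)cc(C)nn23)cc1OC`, gives > 95%, again a limit.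

Compound 3 thus stands at the limit of this assay, and so do the two other compounds shown: the limit of > 95% in this assay, at which 3 of the 3 values shown sit. For the measured compounds named here, no number separates them, and the one measured step, a step that the two limits leave unreadable from compound 1 to compound 2, cannot be read because both ends are limits. Compound 4 is `COc1ccc(-c2c(C)nc3c(N4CC[C@@H](NS(=O)(=O)c5cccs5)C4)cc(C)nn23)cc1OC`. It differs from compound 3 in one place: (thiophen-2-yl)sulfonyl in place of isopropylcarbamoyl on an amine nitrogen. None of the measured steps involves this kind of change, so no measured step bears on it directly; the only guidance is that every compound shown, including compound 3, sits at the limit. The sulfonyl-bearing five-membered aromatic ring that enters is new to this set, and no measured evidence tells how it fares in this assay. Compound 4 is therefore expected to remain mostly intact, but with a real chance of falling below the limit, the expected step being a number at least 13 percentage points lower from compound 3 to compound 4 (beyond the scatter). The estimate for compound 4 in this assay is 82%, within a range from 50% to 97%.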

Compound 4, percent of the compound remaining: > 95%
Compound 4 was reported as a limit; the forecaster's own chance of this, stated with the estimate: 40%; at least 13 percentage points between middle value and limit.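

The step from compound 3 to compound 4 cannot be read, since both results are limits, not numbers: the limit of > 95% in this assay, at which 4 of the 4 values shown sit.

The compounds shown leave open how much of each actually remains in this assay, and so whether (thiophen-2-yl)sulfonyl in place of isopropylcarbamoyl changes anything there.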